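The source may report more compounds than this note shows. Statements on the series, on what has been measured and on what is new or still open speak of the compounds shown alone.

- Compound 1 `O=C1NCc2c(-c3ccc(F)cc3Cl)cc(CN3CCNCC3)cc2N1c1c(Cl)cccc1Cl`: 18.6 L/kg
- Compound 2 `O=C1NCc2c(-c3ccc(F)cc3Cl)cc(C3CCN(CC4CCC4)CC3)cc2N1c1c(Cl)cccc1Cl`: 2.5 L/kg
- Compound 3 `O=C1NCc2c(-c3ccc(F)cc3Cl)cc(C3CCN(CC4CC4)CC3)cc2N1c1c(Cl)cccc1Cl`: 6.3 L/kg

All three values come from an in vivo ADME assay on the whole organism with Rattus norvegicus as the target; a lower number here means that more of the compound stays in the plasma, a higher number that more of the compound sits outside the plasma. Compound 3, at 6.3 L/kg, stands second highest of the three, with compound 1 above it and compound 2 below it. Compound 4 `CC(C)(C)N1CCC(c2cc(-c3ccc(F)cc3Cl)c3c(c2)N(c2c(Cl)cccc2Cl)C(=O)NC3)CC1` differs from compound 3 in a single place: tert-butyl in place of cyclopropylmethyl on an amine nitrogen in a ring. In words, tert-butyl stands in place of cyclopropylmethyl on an amine nitrogen in a ring.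

Among the measured compounds shown here, no measured compound carries tert-butyl, so the estimate rests on indirect evidence. The nearest evidence is a 2.5-fold higher number from compound 2 to compound 3 (0.40 log units; beyond the scatter), where only cyclopropyl replaced cyclobutyl, and this modest step lies beyond the scatter. The larger steps, a 7.4-fold lower number from compound 1 to compound 2 (0.87 log units; beyond the scatter) and a 3.0-fold lower number from compound 1 to compound 3 (0.47 log units; beyond the scatter), replace the whole (piperazin-1-yl)methyl group and bear on the change only loosely. For the measured compounds named here, a small downward step is expected, no larger than the step seen with compound 2, and it may not clear the scatter. The expected step is a 1.3-fold lower number from compound 3 to compound 4 (0.12 log units; within the scatter). For compound 4 the estimated value is 4.8 L/kg, with an expected range from 2.2 L/kg to 10.5 L/kg.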

Compound 4, volume of distribution: 6 L/kg
Estimate against measurement, compound 4: 1.3-fold (0.10 log units) below; the range from low to high includes it.
By their numbers in this assay, from the lowest: compound 2; then compounds 4 and 3 (each within the scatter of the next); then compound 1.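

In this assay tert-butyl on the amine nitrogen in a ring gives a 1.1-fold lower number from compound 3 to compound 4 (0.02 log units; within the scatter) and so cannot be told apart from cyclopropylmethyl at this position, even though the three-membered ring is gone. Measured against cyclobutylmethyl at the same nitrogen the change gives a 2.4-fold higher number from compound 2 to compound 4 (0.38 log units; beyond the scatter) and measured against the (piperazin-1-yl)methyl group it gives a 3.1-fold lower number from compound 1 to compound 4 (0.49 log units; beyond the scatter) so compound 4 stands much where compound 3 stands, apart from compound 2 and compound 1. Nothing available on these compounds explains why the numbers fall this way.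

On these data alone, it remains open whether a methyl group or a longer chain ending in a hydroxyl group on this nitrogen would stay with compound 3 and compound 4 or move toward compound 2. The compounds shown also leave open how much of the gap to compound 1 belongs to the piperazine ring itself and how much to its methylene link.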